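Swapping the ethylpiperidinyl ether for an aminopyrrolidinylpropoxy chain

This account rests on a few compounds, and the source may have more. Where it says the series, first, only, none or still open, it means among the compounds named here.

Compound 1 `CN1CCC(Oc2ccc(-c3nc4ccc(Oc5ccc(Cl)cc5)cc4o3)cc2)CC1`: 19.5%
Compound 2 `CCN1CCC(Oc2ccc(-c3nc4ccc(Oc5ccc(Cl)cc5)cc4o3)cc2)CC1`: 15.3%

Both were tested in an assay on isolated protein for inhibition of advanced glycosylation end product-specific receptor (Homo sapiens), read by FRET, with stated times of 30 min and 1 h, tested at 4 uM; a higher number here means more inhibition at the concentration tested (going by the name of the read-out), a lower number less inhibition. Among the compounds with values here, compound 2, with 15.3%, sits within the scatter of compound 1, the only other measured compound, so neither can be called weaker or stronger. Within the data shown here, the single measured step, a number 4.2 percentage points lower from compound 1 to compound 2 (within the scatter), is no more than noise. Compound 3 `N[C@H]1CCN(CCCOc2ccc(-c3nc4ccc(Oc5ccc(Cl)cc5)cc4o3)cc2)C1` arises from compound 2 by a far larger change: 3-(3-aminopyrrolidin-1-yl)propyl in place of 1-ethylpiperidin-4-yl on an oxygen on an aromatic ring. Among the measured compounds shown here, the measured step touched only the methyl added on the chain carbon bound to the ring amine nitrogen, part of the group that now leaves entirely, so it says little about this exchange; no step involving an aminopyrrolidinyl group or a propyl linker exists here. With both known numbers low and close, compound 3 is expected to show similar low inhibition, with a number 2.7 percentage points higher from compound 2 to compound 3 (within the scatter) amounting to nothing beyond the scatter, although the range is widened for the size of the change. The estimate for compound 3 is 18%, between 2% and 42%.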

Compound 3, a percentage reported as inhibition, at one concentration (the size of the read-out at that concentration, not a potency): 29.9%
For compound 3 the middle estimate is 11.9 percentage points below the measured one, and the stated range covers the measured number.
By their numbers in this assay, from the lowest: compounds 2 and 1 (each within the scatter of the next); then compound 3.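

In this assay, 3-(3-aminopyrrolidin-1-yl)propyl in place of 1-ethylpiperidin-4-yl gives a number 14.6 percentage points higher from compound 2 to compound 3 (beyond the scatter) and in place of 1-methylpiperidin-4-yl gives a number 10.4 percentage points higher from compound 1 to compound 3 (beyond the scatter) as the second reading of the same exchange. The group on this oxygen can therefore move the inhibition beyond the scatter, which the small methyl step between the two piperidines could not show. Nothing measured here explains the gain.

The exchange alters the ring, the linker and the amine all at once, so the compounds shown cannot say which of these parts carries the rise. A 3-(pyrrolidin-1-yl)propyl group without the amine, or a 4-(3-aminopyrrolidin-1-yl)butyl group with a longer chain, would be needed to separate them.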